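Pyridin-4-ylmethyl for Isobutyl: Expected Cell Toxicity

The source may hold more compounds than are shown below. What is called first, only, known or untested is meant among the compounds shown, and "the series" means these compounds.

Three compounds have numbers in an ADME assay on cells (Homo sapiens) for cytotoxicity, read by polymerase chain reaction, with a stated time of 3 days; on this read-out higher numbers stand for lower toxicity in this test and lower numbers for higher toxicity in this test:
Compound 1 `Nc1nc(Cl)c(-c2nc3ccc(Cl)cc3s2)c(N[C@@H]2C[C@H](CO)[C@@H](O)[C@H]2O)n1` gives 16000 nM in this assay.
Compound 2 `Nc1ncc(-c2nc3ccccc3s2)c(N[C@@H]2C[C@H](CO)[C@@H](O)[C@H]2O)n1` reaches only > 25000 nM in this assay, which is a limit of the test and not a number.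
Compound 3 `Cc1nc(NCC(C)C)nc(N[C@@H]2C[C@H](CO)[C@@H](O)[C@H]2O)c1-c1nc2ccccc2s1` gives 10000 nM in this assay.

Compound 3 thus stands among the two real numbers, but compound 1 sits within the scatter of it, so nothing separates the two. One of the three values sits at the limit of > 25000 nM in this assay, at which 1 of the 3 values shown sits. Compound 4 `Cc1nc(NCc2ccncc2)nc(N[C@@H]2C[C@H](CO)[C@@H](O)[C@H]2O)c1-c1nc2ccccc2s1` differs from compound 3 in one place: pyridin-4-yl in place of isopropyl on a saturated chain carbon bound to a nitrogen on an aromatic ring. Going by the values given here, no measured step covers this change, so the expectation rests on compound 3 alone. In this assay the step is expected to be small, most likely none beyond the scatter. Compound 4 is estimated at 12000 nM, with a range of 4000 nM to 30000 nM. That amounts to an expected step of a 1.2-fold higher number from compound 3 to compound 4 (0.08 log units; within the scatter).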

Compound 4, half-maximal cytotoxic concentration: 7000 nM
Compound 4: the middle estimate sits 1.7-fold (0.23 log units) above what was measured, and the stated range covers the measured number.
By their numbers in this assay, from the lowest: compounds 4, 3 and 1 (each within the scatter of the next, the first and the last beyond it). At a limit, above all of these: compound 2.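

In this assay, putting pyridin-4-yl in place of isopropyl on this saturated chain carbon gives a 1.4-fold lower number from compound 3 to compound 4 (0.15 log units; within the scatter), the first step read at this position. A larger group carrying an aromatic ring and a hydrogen-bond acceptor is thus not separated from isopropyl in this test. Nothing among the measurements at hand offers a reason for this result.

On these data alone, whether an amine, a carboxylic acid or a longer chain on this carbon would also stay within the scatter remains open. So does whether pyridin-4-yl would behave the same on another core.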